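Swapping an aryloxy arm for a pyrrolidinylmethyl group

The source may report more compounds than this note shows. Statements on the series, on what has been measured and on what is new or still open speak of the compounds shown alone.

Of the compounds shown here, three sharing one core have been tested in an ADME assay on PC-3 cells (Homo sapiens) for cytotoxicity, read by WST assay, tested at 100 uM; a higher number here means more inhibition at the concentration tested (going by the name of the read-out), a lower number less inhibition. Compound 1 `O=C(Nc1cccc(Oc2nccc(C(F)(F)F)c2Cl)c1)C1CCCN(C(=O)c2cc(C(F)(F)F)cc(C(F)(F)F)c2)C1` gives 0%. Compound 2 `COc1cccc(C(=O)N2CCCC(C(=O)Nc3ccc(Cl)cc3)C2)c1` gives 0%, and compound 3 `COC(=O)c1cccc(C(=O)N2CCCC(C(=O)Nc3ccc(Cl)cc3)C2)c1` gives 0%. Among the compounds with values here, the one measured step, no change at the digits printed from compound 2 to compound 3 (within the scatter), stays flat. Compound 1 therefore stands level with compounds 2 and 3, all three showing no measurable inhibition at the concentration tested.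

Compound 4 `O=C(Nc1cccc(CN2CCCC2)c1)C1CCCN(C(=O)c2cc(C(F)(F)F)cc(C(F)(F)F)c2)C1` differs from compound 1 in one place: (pyrrolidin-1-yl)methyl in place of (3-chloro-4-(trifluoromethyl)pyridin-2-yl)oxy on an aromatic carbon. Within the data shown here, no measured step touches this kind of change; the step from compound 2 to compound 3 alters a different part of the molecule and was itself within the scatter, so it offers no direction. With every measured compound at the same flat reading, the expectation is that compound 4 also shows no inhibition beyond the scatter, with no change at the digits printed from compound 1 to compound 4 (within the scatter) as the expected step. Compound 4 is therefore estimated at 0%, in a range from -10% to 15%.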

Compound 4, a percentage reported as inhibition, at one concentration (the size of the read-out at that concentration, not a potency): 51%
Estimate against measurement, compound 4: 51 percentage points below, and the stated range ends below it.
By their numbers in this assay, from the lowest: compounds 1, 2 and 3 (each within the scatter of the next); then compound 4.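

At this position, on an aromatic carbon meta to a large group, replacing (3-chloro-4-(trifluoromethyl)pyridin-2-yl)oxy with (pyrrolidin-1-yl)methyl in this assay gives a number 51 percentage points higher from compound 1 to compound 4 (beyond the scatter). Within the data shown here, the flat readings of the earlier compounds could not show this: the reading can move, and this one exchange is enough to move it. No measured information bears on why the reading rises.

This single step changes several things at once, from an aromatic ring to a non-aromatic one and from 12 heavy atoms to 6, so the compounds shown do not separate their contributions. Open too, on these data alone, is how the reading would respond to a cyclopentylmethyl group, which has carbon where the pyrrolidine has its nitrogen, or to an open-chain diethylaminomethyl group.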